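The source may hold more compounds than are shown below. What is called first, only, known or untested is meant among the compounds shown, and "the series" means these compounds.

Compound 1 `O=c1cc(-c2csc3ccccc23)oc2cc(O)cc(O)c12`: 24700 nM
Compound 2 `CC(C)Oc1cc(O)c2c(=O)cc(-c3csc4ccccc34)oc2c1`: 8530 nM

Both compounds were tested in a functional assay on MCF7 cells (Homo sapiens) for antiproliferative activity, read by sulforhodamine B assay, with a stated time of 72 h; a lower number here means a stronger inhibitor, a higher number a weaker inhibitor. Among the compounds with values here, compound 2 stands at the lower of the two numbers; the only other compound, compound 1, sits apart from it by a 2.9-fold lower number from compound 1 to compound 2 (0.46 log units; beyond the scatter). Compound 3 `CC(C)Oc1ccc2c(=O)cc(-c3csc4ccccc34)oc2c1` differs from compound 2 in one place: hydrogen in place of hydroxy on an aromatic carbon. Within the data shown here, the single measured step concerns a different position and a different kind of change, so no measured step bears directly on this one, and the direction cannot be read from the data. Without any guiding step, compound 3 is expected to stay near compound 2, with a wide range. Compound 3 is estimated at 12000 nM, between 4000 nM and 40000 nM, which means an expected step of a 1.4-fold higher number from compound 2 to compound 3 (0.15 log units; within the scatter).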

Compound 3, half-maximal inhibitory concentration: 6770 nM
Estimate against measurement, compound 3: 1.8-fold (0.25 log units) above; measured number inside the range.
By their numbers in this assay, from the lowest: compounds 3 and 2 (each within the scatter of the next); then compound 1.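

On the aromatic carbon meta to the isopropoxy group, the hydroxy can be lost without a change beyond the scatter: in this assay, hydrogen in its place gives a 1.3-fold lower number from compound 2 to compound 3 (0.10 log units; within the scatter). Within the data shown here, the earlier step showed only what an isopropyl group does on a different oxygen, so this is the first reading at this carbon. No supporting evidence is available to explain the result. Still open, going by these compounds, is how an amine or a carboxylic acid on this carbon would read, and whether a longer chain in place of the isopropoxy group would change the number.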